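Moving the carboxyl group around the ring in a positive modulator series

The compounds below may be only part of what the source reports. "The series", "measured", "known", "first", "only" and "open" are said of these compounds alone.

Measured so far:
compound 1, `Cc1c(OCCCCOc2ccc(C(=O)O)cc2)ccc(C(=O)CC(C)C)c1O`, 122 nM
compound 2, `Cc1c(OCCCCOc2ccccc2C(=O)O)ccc(C(=O)CC(C)C)c1C`, 976 nM
compound 3, `Cc1c(OCCCCOc2cccc(C(=O)O)c2)ccc(C(=O)CC(C)C)c1O`, 222 nM

In an assay on HEK293 cells for positive allosteric modulation of metabotropic glutamate receptor 2 (Rattus norvegicus), read by thallium flux, with a stated time of 2.5 min (on this read-out higher numbers stand for an effect only at larger amounts of compound and lower numbers for an effect already at smaller amounts), compound 3 gives the second highest of the three numbers. Its nearest neighbour is compound 1, and the step of a 1.8-fold higher number from compound 1 to compound 3 (0.26 log units; within the scatter) lies within the scatter, so the two cannot be ordered. Compound 2 lies furthest away, with a higher number than compound 3, beyond the scatter.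

Compound 4, `Cc1c(OCCCCOc2ccccc2C(=O)O)ccc(C(=O)CC(C)C)c1O`, is not yet measured. It differs from compound 3 in one place: 2-carboxyphenyl in place of 3-carboxyphenyl on an oxygen on a saturated carbon. Among the measured compounds shown here, only one measured step bears directly on a move of the carboxyl group, namely a 1.8-fold higher number from compound 1 to compound 3 (0.26 log units; within the scatter), and it was small. Compound 2 also bears a 2-carboxyphenyl but differs from compound 4 elsewhere in the core; the value of compound 2, 976 nM, can only hint that this arrangement may give a higher number in this assay. Compound 4 is therefore expected to give 500 nM, in a range from 180 nM to 1400 nM, corresponding to an estimated step of a 2.3-fold higher number from compound 3 to compound 4 (0.35 log units; beyond the scatter).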

Compound 4, half-maximal effective concentration: 415 nM
The estimate for compound 4 lay 1.2-fold (0.08 log units) above the measured number; the measured number falls inside the stated range.
By their numbers in this assay, from the lowest: compounds 1, 3 and 4 (each within the scatter of the next, the first and the last beyond it); then compound 2.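

With the core held fixed, this assay now separates two carboxyl placements on the oxygen-bearing chain: 2-carboxyphenyl in place of 4-carboxyphenyl gives a 3.4-fold higher number from compound 1 to compound 4 (0.53 log units; beyond the scatter) and so lies beyond the scatter. The 3-carboxyphenyl compound cannot be ordered against the 2-carboxyphenyl one, since the change gives only a 1.9-fold higher number from compound 3 to compound 4 (0.27 log units; within the scatter) and stays within the scatter. Among the compounds shown here, the comparison also isolates a second place for the first time: with 2-carboxyphenyl kept, hydroxy in place of methyl on the aromatic carbon gives a 2.4-fold lower number from compound 2 to compound 4 (0.37 log units; beyond the scatter) and so lies beyond the scatter.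

From the compounds shown here alone, it remains open whether that hydroxy-for-methyl step carries over to the 3-carboxyphenyl and 4-carboxyphenyl compounds, and how a tetrazole or an amide in place of the carboxylic acid would read. Nothing shown here bears on what lies behind either step.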